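Swapping diethylamino for isopropoxy on an ester series

The source may report more compounds than this note shows. Statements on the series, on what has been measured and on what is new or still open speak of the compounds shown alone.

Compound 1 `CCN(CC)c1ccc(-c2ccc(C(C)=O)cc2)nn1` gives 25000 nM
Compound 2 `CCN(CC)c1ccc(-c2ccc(C(=O)OC)cc2)nn1` gives 90 nM
Compound 3 `CCOC(=O)c1ccc(-c2ccc(N(CC)CC)nn2)cc1` gives 9000 nM

These values come from a functional assay on Huh-7 cells (Homo sapiens) for antiproliferative activity, with a stated time of 48 h; on this read-out higher numbers stand for weaker inhibition and lower numbers for stronger inhibition. Compound 3 holds the second highest of the three numbers, with a 2.8-fold lower number from compound 1 to compound 3 (0.44 log units; beyond the scatter) and, on the other side, a 100-fold higher number from compound 2 to compound 3 (2.00 log units; beyond the scatter). Compound 4 `CCOC(=O)c1ccc(-c2ccc(OC(C)C)nn2)cc1` carries isopropoxy in place of diethylamino on an aromatic carbon.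

Among the compounds with values here, none of the measured steps touches this place, since all three compounds keep diethylamino and differ only at the carbonyl. They therefore give no direction for the change. They do show how far a small edit can move the number in this assay, as in a 280-fold lower number from compound 1 to compound 2 (2.44 log units; beyond the scatter) and a 100-fold higher number from compound 2 to compound 3 (2.00 log units; beyond the scatter), so a wide range is warranted. With no direction to go on, the expectation stays close to the parent, and the expected step is no change at the digits printed from compound 3 to compound 4 (within the scatter). For compound 4 the estimated value is 9000 nM, with an expected range from 2000 nM to 40000 nM.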

Compound 4, half-maximal inhibitory concentration: > 25000 nM
Compound 4: only a limit was reported; the forecaster's own chance of this, stated with the estimate: 10%; at least 2.7-fold (0.44 log units) between middle value and limit.
By their numbers in this assay, from the lowest: compound 2; then compound 3; then compound 1.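

In this assay, compound 4 is reported only as a limit, > 25000 nM. This gives the position its first direction: with the ethyl ester held constant, the change from diethylamino to isopropoxy on the aromatic carbon gives an at least 2.7-fold higher number from compound 3 to compound 4 (0.44 log units; beyond the scatter). The true size of this step cannot be read, and the printed figure is only a minimum: the limit of > 25000 nM in this assay, at which 1 of the 4 values shown sits.

The compounds shown leave open whether the same swap would move the number on the methyl ester of compound 2, which gives 90 nM. Within the data shown here, they also leave open how a dimethylamino group or a methoxy group would read at this place, so the single step cannot yet separate the effect of the amine nitrogen from that of the particular groups compared.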